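Nitrogen substituent series on the shared indole-type core

The source may hold more compounds than are shown below. What is called first, only, known or untested is meant among the compounds shown, and "the series" means these compounds.

Measured so far:
- compound 1 `COc1cccc(CNC(=O)c2cn(CCN(C)C)c3cc(-c4cn[nH]c4)ccc23)c1`: 5 nM
- compound 2 `COc1cccc(CNC(=O)c2cn(-c3ccccc3)c3cc(-c4cn[nH]c4)ccc23)c1`: 21 nM

Compound 2 stands at the higher of the two numbers in an assay on isolated protein for inhibition of Rho-associated protein kinase 1 (Homo sapiens); on this read-out higher numbers stand for weaker inhibition and lower numbers for stronger inhibition; its nearest neighbour is compound 1, and the step of a 4.2-fold higher number from compound 1 to compound 2 (0.62 log units; beyond the scatter) lies beyond the scatter. Compound 3 `COc1cccc(CNC(=O)c2cn(C)c3cc(-c4cn[nH]c4)ccc23)c1` has not yet been measured in this assay. The change from compound 2 to compound 3 is methyl in place of phenyl on an aromatic nitrogen. Among the measured compounds shown here, no measured step places a methyl on that aromatic nitrogen, so the only step that bears on it is a 4.2-fold higher number from compound 1 to compound 2 (0.62 log units; beyond the scatter), a modest step that runs from a 2-(dimethylamino)ethyl to a phenyl. Replacing the phenyl with a methyl removes the group that accompanied that higher number, so the expectation for compound 3 is a number somewhat lower than that of compound 2, with the step of a 2.1-fold lower number from compound 2 to compound 3 (0.32 log units; beyond the scatter) expected to be modest. Compound 3 is estimated at 10 nM in this assay, within a range of 3 nM to 35 nM.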

Compound 3, half-maximal inhibitory concentration: < 1 nM
Compound 3 gave a limit, no number; the forecaster's own chance of this, stated with the estimate: 2%; at least 10-fold (1.00 log units) between middle value and limit.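

In this assay compound 3 gives < 1 nM, which is a limit of the assay and not a number: the limit of < 1 nM in this assay, at which 1 of the 3 values shown sits.

On this aromatic nitrogen, methyl in place of phenyl gives an at least 21-fold lower number from compound 2 to compound 3 (1.32 log units; beyond the scatter), and hydrogen in place of (dimethylamino)methyl on the saturated chain carbon gives an at least 5.0-fold lower number from compound 1 to compound 3 (0.69 log units; beyond the scatter). The first pair alone could not show whether the low number of compound 1 depended on its 2-(dimethylamino)ethyl; compound 3 shows that neither that chain nor a ring on this nitrogen is needed for strong inhibition in this set.

From the compounds shown here alone, it remains open how plain hydrogen, an ethyl or a longer carbon chain without the amine would read at this nitrogen. Whether methyl is a singular best point or part of a wider trend also stays unresolved.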